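Two thioureas at the assay limit

A few compounds are considered here, and "the series" means these few. Any claim that something is new, unique, unknown or untested is made for them only; others in the source may bear on it.

Measured so far in a functional assay with Rattus norvegicus as the target; a higher number here means that more compound is needed for the effect, a lower number that less compound is needed:
- Compound 1 `C[C@@H](/N=C(\S)NCc1ccc(C(C)(C)C)cc1)c1ccc(N)cc1`: > 100000 nM (a limit)
- Compound 2 `C[C@@H](/N=C(\S)NCc1ccc(C(C)(C)C)cc1)c1ccc(C(C)(C)C)cc1`: > 100000 nM (a limit)

Compound 2 has no number, only a limit of the assay, and compound 1 likewise. Both sit at the same limit: the limit of > 100000 nM in this assay, at which 2 of the 2 values shown sit. Within the data shown here, the only measured step is a step that the two limits leave unreadable from compound 1 to compound 2. Compound 3 `CC(=O)Nc1ccc([C@@H](C)/N=C(\S)NCc2ccc(C(C)(C)C)cc2)cc1` carries acetamido in place of tert-butyl on an aromatic carbon, para to a large group (acetamido in place of tert-butyl on an aromatic carbon). Among the measured compounds shown here, with no sized step to draw on, no change beyond the scatter is expected in this assay, and a limit reading is quite likely. For compound 3 the estimate is 80000 nM, with an expected range of 10000 nM to 200000 nM. This means an expected at least 1.2-fold lower number from compound 2 to compound 3 (0.09 log units; that floor lies within the scatter).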

Compound 3, half-maximal effective concentration: > 100000 nM
Compound 3 was reported as a limit (the forecaster's own chance of this, stated with the estimate: 65%); middle value at least 1.2-fold (0.09 log units) from the limit.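

Among these compounds, compound 3, like compound 1 and compound 2, is reported only as a limit, and no step among the three can be read: the limit of > 100000 nM in this assay, at which 3 of the 3 values shown sit. The compounds shown leave open whether any group at this place gives a readable value in this assay.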